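The source may hold more compounds than are shown below. What is called first, only, known or untested is meant among the compounds shown, and "the series" means these compounds.

Measured in a functional assay on MGC-803 cells (Homo sapiens) for antiproliferative activity, read by MTT assay, with a stated time of 48 h; on this read-out higher numbers stand for weaker inhibition and lower numbers for stronger inhibition:
compound 1 `COc1ccc(CN(C(=O)Cn2cc(CSC3=NCCS3)nn2)c2cc(OC)c(OC)c(OC)c2)cc1`: 1610 nM
compound 2 `COc1ccc(CN(C(=O)Cn2cc(CSc3nnc(-c4ccccc4)c(-c4ccccc4)n3)nn2)c2cc(OC)c(OC)c(OC)c2)cc1`: 1520 nM

For the measured compounds named here, compound 1 at 1610 nM and compound 2 at 1520 nM lie within the scatter of each other, so compound 1 stands level with the only other measured compound. The next compound to be measured is compound 3 `COc1ccc(CN(C(=O)Cn2cc(CNS(=O)(=O)c3ccc(C)cc3)nn2)c2cc(OC)c(OC)c(OC)c2)cc1`. Relative to compound 1, it carries this change: a group of 11 heavy atoms (7 carbon, 1 nitrogen, 2 oxygen, 1 sulfur; one six-membered aromatic ring of carbon only) in place of a group of 6 heavy atoms (3 carbon, 1 nitrogen, 2 sulfur; one five-membered non-aromatic ring with 2 hetero atoms), on a saturated chain carbon bound to an aromatic carbon. The group entering is ((4-methylphenyl)sulfonyl)amino, on a saturated chain carbon bound to an aromatic carbon. Going by the values given here, no measured step bears on this change, so the expectation is weakly founded. No step beyond the scatter is expected in this assay, in either direction. The expected change is a 1.1-fold higher number from compound 1 to compound 3 (0.05 log units; within the scatter). For compound 3 the estimated value is 1800 nM, with an expected range of 500 nM to 7000 nM.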

Compound 3, half-maximal inhibitory concentration: 1580 nM
For compound 3 the middle estimate is 1.1-fold (0.06 log units) above the measured one; low and high end bracket the measured number.
By their numbers in this assay, from the lowest: compounds 2, 3 and 1 (each within the scatter of the next).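

In this assay, for the compounds shown here, the one step read on a saturated chain carbon bound to an aromatic carbon is a 1.0-fold lower number from compound 1 to compound 3 (0.01 log units; within the scatter), with ((4-methylphenyl)sulfonyl)amino entering. This place therefore takes a group of 11 heavy atoms with a six-membered aromatic ring of carbon only instead of a group of 6 heavy atoms with a five-membered non-aromatic ring, and the two values stay within the scatter of each other. No supporting measurement accounts for this outcome or assigns a property to either group.

Going by these compounds, whether an amine or a carboxylic acid at this place would give a step beyond the scatter remains open. Also open, on these data alone, is what a longer chain between the aromatic carbon and the sulfonylamino group would do.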